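A few compounds are considered here, and "the series" means these few. Any claim that something is new, unique, unknown or untested is made for them only; others in the source may bear on it.

In a functional assay on HEK293 cells for activation of melanin-concentrating hormone receptor 1 (Rattus norvegicus), read by inositol phosphate accumulation (a lower number here means that less compound is needed, a higher number that more compound is needed for the effect), two compounds of this series have been characterised. Compound 1 `CC1CCN(c2ccc3cc(NC(=O)CCc4ccc(C(F)(F)F)cc4)ccc3n2)C1` gives 400 nM, while compound 2 `CC(C)C(=O)NC1CCN(c2ccc3cc(NC(=O)CCc4ccc(C(F)(F)F)cc4)ccc3n2)C1` gives 90 nM. For the measured compounds named here, the one recorded step, a 4.4-fold lower number from compound 1 to compound 2 (0.65 log units; beyond the scatter), shows that putting (isopropylcarbonyl)amino in place of methyl on a saturated ring carbon brought a modest gain, so compound 2 stands at the lowest of the two numbers in this assay, with compound 1 as its only neighbour.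

Compound 3 `O=C(CCc1ccc(C(F)(F)F)cc1)Nc1ccc2nc(N3CC4CC3CO4)ccc2c1` has not yet been measured. It differs from compound 2 as follows: a group of 7 heavy atoms (5 carbon, 1 nitrogen, 1 oxygen; 2 five-membered non-aromatic rings with 1 hetero atom each) in place of a group of 11 heavy atoms (8 carbon, 2 nitrogen, 1 oxygen; one five-membered non-aromatic ring with 1 hetero atom), on an aromatic carbon. The group that leaves is the one whose (isopropylcarbonyl)amino arm carried the gain seen in the step from compound 1 to compound 2; the group that enters has no hydrogen-bond donor and is smaller. Going by the values given here, no measured step covers a change of this kind, so the only guidance is that the pyrrolidine bearing (isopropylcarbonyl)amino was worth something relative to a plain methyl-bearing pyrrolidine. On that basis compound 3 is expected to move back toward the level of compound 1, with a 3.3-fold higher number from compound 2 to compound 3 (0.52 log units; beyond the scatter) as the expected step. The estimate for compound 3 in this assay is 300 nM, with a range from 80 nM to 1200 nM.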

Compound 3, half-maximal effective concentration: 70 nM
Compound 3: the middle estimate sits 4.3-fold (0.63 log units) above what was measured; measured number outside the range, below it.
By their numbers in this assay, from the lowest: compounds 3 and 2 (each within the scatter of the next); then compound 1.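

In this assay, the change at this position, on an aromatic carbon next to the ring nitrogen, gives a 1.3-fold lower number from compound 2 to compound 3 (0.11 log units; within the scatter), so the level of compound 2 does not depend on the 3-((isopropylcarbonyl)amino)pyrrolidin-1-yl group or its hydrogen-bond donor: a smaller group with two five-membered non-aromatic rings and no donor does as well. Set against the methyl-bearing ring of compound 1, the same group gives a 5.7-fold lower number from compound 1 to compound 3 (0.76 log units; beyond the scatter), which shows that a change of only a few atoms at this position can match what the much larger (isopropylcarbonyl)amino arm achieved. Nothing available explains why two such different groups end up within the scatter of each other.

The compounds shown leave open which feature of the entering group matters, the ring oxygen or the second ring, since a morpholine or an unsubstituted pyrrolidine at this position would separate the two. They also leave open whether a free amine or a carboxylic acid on the ring would be tolerated here.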